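Compound 2 to compound 3: a (2-methoxybenzyl)amino swap

A few compounds are considered here, and "the series" means these few. Any claim that something is new, unique, unknown or untested is made for them only; others in the source may bear on it.

In a functional assay on cells (Homo sapiens) for cytotoxicity, read by MTT assay, with a stated time of 24 h (on this read-out higher numbers stand for weaker inhibition and lower numbers for stronger inhibition), compound 1 (`CCCCCCCCCCCCCCNC(=O)[C@H](CO)/N=C/c1ccccc1Cl`) gives 10300 nM and compound 2 (`CCCCCCCCCCCCCCNC(=O)[C@H](CO)/N=C/c1ccccc1O`) gives 19000 nM as its reading. Among the measured compounds shown here, these two numbers lie within the scatter of each other, so compound 2 cannot be told apart from its only measured neighbour. Compound 3 (`CCCCCCCCCCCCCCNC(=O)[C@H](CO)NCc1ccccc1OC`) keeps the long chain but differs from compound 2 in one place (a group of 10 heavy atoms (8 carbon, 1 nitrogen, 1 oxygen; one six-membered aromatic ring of carbon only) in place of a group of 9 heavy atoms (7 carbon, 1 nitrogen, 1 oxygen; one six-membered aromatic ring of carbon only), on a saturated chain carbon bound to a carbonyl carbon and a saturated chain carbon) where a (2-methoxybenzyl)amino group now stands. The double bond outside the aromatic ring is gone, and the ring carries methoxy instead of hydroxy. For the measured compounds named here, the one measured step (a 1.8-fold higher number from compound 1 to compound 2 (0.27 log units; within the scatter)) exchanges only a group on the ring. It is small, which suggests that a ring-group swap alone need not shift the reading much. Going by the values given here, no measured pair covers the loss of the double bond, so that part of the change remains open and the range must stay wide. The expected result in this assay is no step beyond the scatter (a 1.6-fold lower number from compound 2 to compound 3 (0.20 log units; within the scatter)) for this change. For compound 3 the estimated value is 12000 nM with an expected range from 5000 nM to 28000 nM in this read-out.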

Compound 3, half-maximal inhibitory concentration: 100000 nM
For compound 3 the middle estimate is 8.3-fold (0.92 log units) below the measured one, and the stated range ends below it.
By their numbers in this assay, from the lowest: compounds 1 and 2 (each within the scatter of the next); then compound 3.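

In this assay, this position responds to the swap: placing (2-methoxybenzyl)amino on the saturated chain carbon bound to a carbonyl carbon and a saturated chain carbon gives a 5.3-fold higher number from compound 2 to compound 3 (0.72 log units; beyond the scatter) and moves the reading towards weaker inhibition. The same group, entering in place of the chlorine-bearing group, gives a 9.7-fold higher number from compound 1 to compound 3 (0.99 log units; beyond the scatter) and points the same way, whereas the exchange of chloro for hydroxy on the ring gave only a 1.8-fold higher number from compound 1 to compound 2 (0.27 log units; within the scatter) and stayed within the scatter. So a larger edit at this position, one that removes the double bond outside the aromatic ring as well as swapping the ring group, can shift this read-out beyond the scatter, though no measurement shown here accounts for the shift.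

The step from compound 2 to compound 3 bundles these two edits, so the compounds shown cannot say how much of it belongs to the lost double bond and how much to the methoxy. From the compounds shown here alone, a partner carrying (2-hydroxybenzyl)amino at this place would separate the two, and whether a different ring group, such as a carboxylic acid, would behave alike remains open.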